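Two fluorines in place of an amine: an expectation

A few compounds are considered here, and "the series" means these few. Any claim that something is new, unique, unknown or untested is made for them only; others in the source may bear on it.

Compound 1 `COc1cc(-c2cc(/C=C/C(=O)c3ccc(N)cc3)[nH]n2)cc(OC)c1OC` gives 9810 nM in a functional assay on NCI-H522 cells (Homo sapiens) for inhibition, read by sulforhodamine B assay, with a stated time of 48 h; on this read-out higher numbers stand for lower toxicity in this test and lower numbers for higher toxicity in this test. Among the measured compounds shown here, that is the higher of the two numbers known here, though compound 2 `COc1ccc(C(=O)/C=C/c2cc(-c3cc(OC)c(OC)c(OC)c3)n[nH]2)cc1`, which gives 6970 nM in this assay, sits within the scatter of it: the step of a 1.4-fold lower number from compound 1 to compound 2 (0.15 log units; within the scatter) is small. Compound 3 `COc1cc(-c2cc(/C=C/C(=O)c3ccc(F)c(F)c3)[nH]n2)cc(OC)c1OC` differs from compound 1 by 3,4-difluorophenyl in place of 4-aminophenyl on a carbonyl carbon. For the measured compounds named here, only the step from compound 1 to compound 2, which also changes the group on that ring, bears on this change, and it was within the scatter; no step beyond the scatter is therefore expected in this assay. Compound 3 is estimated at 7500 nM, between 2500 nM and 25000 nM, meaning an expected step of a 1.3-fold lower number from compound 1 to compound 3 (0.12 log units; within the scatter).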

Compound 3, concentration lethal to 50% of the cells: 65200 nM
Compound 3: the middle estimate sits 8.7-fold (0.94 log units) below what was measured; the measured number lies above the stated range.
By their numbers in this assay, from the lowest: compounds 2 and 1 (each within the scatter of the next); then compound 3.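

The group on the carbonyl carbon does matter in this assay: the change to 3,4-difluorophenyl gives a 6.6-fold higher number from compound 1 to compound 3 (0.82 log units; beyond the scatter) and a 9.4-fold higher number from compound 2 to compound 3 (0.97 log units; beyond the scatter), both beyond the scatter. Compound 1 and compound 2 lie within the scatter of each other, so the step between them gave no sign of this sensitivity. Compound 3 therefore shows the lowest toxicity in this test of the three. Nothing available here explains the rise. Going by these compounds, whether it takes both fluorines remains open; 4-fluorophenyl or unsubstituted phenyl on the same carbon would help separate them.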